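Moving the Bromine on a Benzyl Group

The source may hold more compounds than are shown below. What is called first, only, known or untested is meant among the compounds shown, and "the series" means these compounds.

Compound 1 `COC(=O)c1ccc(NCc2cncn2Cc2cccc(Br)c2)cc1-c1ccccc1` was tested in a toxicity assay on NIH3T3 cells (Mus musculus) for cytotoxicity, read by resazurin assay; a lower number here means that less compound is needed, a higher number that more compound is needed for the effect. Compound 1 gives > 10000 nM here, which is a limit of the assay rather than a number. A second compound, compound 2 `CNC(=O)c1ccc(NCc2cncn2Cc2ccc(-c3ccccc3)cc2)cc1-c1ccccc1`, also gives only a limit in this assay, namely > 1000 nM. Neither of the two known values therefore fixes where compound 1 stands; it is known only to sit at the limit of > 10000 nM in this assay, at which 1 of the 2 values shown sits. The new compound 3 `COC(=O)c1ccc(NCc2cncn2Cc2ccccc2Br)cc1-c1ccccc1` keeps the same atoms as compound 1 but joins them differently: 2-bromophenyl in place of 3-bromophenyl on a saturated chain carbon bound to an aromatic nitrogen. For the measured compounds named here, no step between two measured compounds is available to show what such a change does in this assay. With both known values sitting at limits, the step that the limit leaves unreadable from compound 1 to compound 3 is expected to lie within the usual scatter. Compound 3 is therefore estimated at 20000 nM, with a range from 5000 nM to 80000 nM, and will most likely again be reported only as a limit.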

Compound 3, half-maximal effective concentration: 10000 nM
The estimate for compound 3 lay 2.0-fold (0.30 log units) above the measured number, and the stated range covers the measured number.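

In this assay compound 3 gives 10000 nM, a measured number, and so 2-bromophenyl in this place provides the first readable value among the compounds shown. Compound 1 stays a limit of the assay, so the move of the bromine gives only a direction, a number no higher from compound 1 to compound 3 (the limit leaves the size open): the limit of > 10000 nM in this assay, at which 1 of the 3 values shown sits. The change could therefore be very small or much larger, and the two compounds show only that moving the bromine does not raise the number.

As far as these compounds go, how far compound 1 really lies from compound 3 stays unknown. Compound 2 differs from both in more than one place, and it cannot help here. Also open, from the compounds shown here alone, is what an amine or a carboxylic acid in place of the bromine on the benzyl group would do to the number in this assay.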